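The compounds below may be only part of what the source reports. "The series", "measured", "known", "first", "only" and "open" are said of these compounds alone.

Measured compounds:
- compound 1, `C=CCNc1nc(NCc2ccc(C(=O)Nc3ccc(F)cc3)cc2)c2ccccc2n1`: 14000 nM
- compound 2, `CC1CN(c2nc(NCc3ccc(C(=O)Nc4ccc(F)cc4)cc3)c3ccccc3n2)CCN1`: 2800 nM

In a functional assay on HCT-116 cells (Homo sapiens) for inhibition, read by luminescence and resazurin assay, with a stated time of 3 days (a higher number here means a weaker inhibitor, a lower number a stronger inhibitor), compound 2 gives the lowest of the two numbers recorded, and the nearest is compound 1 with 14000 nM, a gap that lies beyond the scatter. Going by the values given here, the single step between them, a 5.0-fold lower number from compound 1 to compound 2 (0.70 log units; beyond the scatter), was modest in size and came with 3-methylpiperazin-1-yl in place of allylamino on an aromatic carbon.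

Compound 3, `CCCCNc1nc(NCc2ccc(C(=O)Nc3ccc(F)cc3)cc2)c2ccccc2n1`, is not yet measured. It differs from compound 2 by butylamino in place of 3-methylpiperazin-1-yl on an aromatic carbon. Among the compounds with values here, the one step that bears on this change is the step from compound 1 to compound 2, because in it a 5.0-fold lower number from compound 1 to compound 2 (0.70 log units; beyond the scatter) accompanied the arrival of 3-methylpiperazin-1-yl in place of an acyclic amino group. Compound 3 carries butylamino, again an acyclic amino group with one hydrogen-bond donor, so the expectation is that the number in this assay moves back toward that of compound 1, a step of a 3.6-fold higher number from compound 2 to compound 3 (0.55 log units; beyond the scatter), roughly undoing the earlier gain. Compound 3 is therefore estimated at 10000 nM, with a range from 3500 nM to 30000 nM.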

Compound 3, half-maximal inhibitory concentration: 1400 nM
Compound 3: middle estimate off by 7.1-fold (0.85 log units), on the high side; the measured number lies below the stated range.
By their numbers in this assay, from the lowest: compounds 3 and 2 (each within the scatter of the next); then compound 1.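

In this assay the step of a 2.0-fold lower number from compound 2 to compound 3 (0.30 log units; within the scatter) shows that, on this aromatic carbon between two ring nitrogen atoms, butylamino and 3-methylpiperazin-1-yl are not told apart, so a number at this level does not require the ring carried by compound 2. The earlier step had set that ring against allylamino alone and could not show this. Going by these compounds alone, the step of a 10-fold lower number from compound 1 to compound 3 (1.00 log units; beyond the scatter) adds that the two open-chain groups are told apart, with propyl in place of vinyl and no ring in either compound, so the nature of the chain matters at this position and compound 1 stands apart from the other two.

Butylamino differs from allylamino in both chain length and the double bond, and the compounds shown cannot separate the two; propylamino would be the direct test. They also leave open how far the chain can grow, as in hexylamino, and whether morpholine or unsubstituted piperazine would match the 3-methylpiperazin-1-yl group. No separate measurement is available to account for any of these differences.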